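The source may report more compounds than this note shows. Statements on the series, on what has been measured and on what is new or still open speak of the compounds shown alone.

Compound 1 `O=C(Nc1cccc(-c2ccco2)c1)C1CCCN(C(=O)c2cc(C(F)(F)F)cc(C(F)(F)F)c2)C1` was examined in an ADME assay on PC-3 cells (Homo sapiens) for cytotoxicity, read by WST assay, tested at 100 uM; on this read-out lower numbers stand for less inhibition and higher numbers for more inhibition at the one concentration tested (going by the name of the read-out). In that test compound 1 gives 0%. A second member of the same series, compound 2 `O=C(Nc1ccc(Cl)cc1)C1CCCN(C(=O)c2cccc([N+](=O)[O-])c2)C1`, carries a different pair of substituents on the shared core, and in this assay compound 2 gives 0%. On these two numbers compound 1 stands level with compound 2 at the digits reported; the values lie within the scatter of each other, so neither compound can be placed above the other.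

Compound 3 `O=C(Nc1cccc(Oc2nccc(C(F)(F)F)c2Cl)c1)C1CCCN(C(=O)c2cc(C(F)(F)F)cc(C(F)(F)F)c2)C1` has not yet been measured in this assay. It differs from compound 1 in a single place: (3-chloro-4-(trifluoromethyl)pyridin-2-yl)oxy in place of furan-2-yl on an aromatic carbon. Among the measured compounds shown here, no step between two measured compounds traces this kind of change, so its effect in this assay cannot be read from the series itself. What the data do show is that compound 1 gives 0% and compound 2 gives 0%, both without detectable inhibition. Compound 3 is therefore expected to move by a number 5 percentage points higher from compound 1 to compound 3 (within the scatter), a shift that likely stays within the scatter. Compound 3 is estimated at 5%, with a plausible range from 0% to 25%.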

Compound 3, a percentage reported as inhibition, at one concentration (the size of the read-out at that concentration, not a potency): 0%
Compound 3: the middle estimate sits 5 percentage points above what was measured; measured number inside the range.
By their numbers in this assay, from the lowest: compounds 1, 2 and 3 (each within the scatter of the next).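

In this assay, putting (3-chloro-4-(trifluoromethyl)pyridin-2-yl)oxy in place of furan-2-yl on an aromatic carbon, meta to a large group, shows no change at the digits printed from compound 1 to compound 3 (within the scatter). Among the compounds shown here, this is the only step that can be read at this position, and the earlier pair, which differs in more than one place, could not show it. The read-out at the one concentration tested thus does not separate furan-2-yl, with its 5 heavy atoms and five-membered aromatic ring, from an entering group with 12 heavy atoms and a six-membered aromatic ring, and nothing at hand accounts for this result.

With all three compounds level in this assay, the compounds shown do not reveal whether any group at this position can raise the read-out, and a single step says nothing about other replacements. From the compounds shown here alone, it remains open whether an amine or a carboxylic acid on this aromatic carbon would read any differently, and whether the same exchange would behave alike with the other substituents of compound 2.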